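Ester replaced by oxazole on the core of compound 3

The source may report more compounds than this note shows. Statements on the series, on what has been measured and on what is new or still open speak of the compounds shown alone.

Three compounds share a core and differ only in the aryl group on a saturated ring carbon. Compound 1 `CCCOC(=O)C1=C(C)NC(=O)NC1c1ccoc1` gives 1190 nM in an assay on membranes from HEK293 cells for displacement of a labelled ligand from adenosine receptor A2b (Homo sapiens), read by scintillation counting, with a stated time of 30 min; on this read-out lower numbers stand for stronger inhibition and higher numbers for weaker inhibition. Compound 2 `CCCOC(=O)C1=C(C)NC(=O)NC1c1cccs1` gives 1520 nM, and the step of a 1.3-fold higher number from compound 1 to compound 2 (0.11 log units; within the scatter) lies within the scatter. Compound 3 `CCCOC(=O)C1=C(C)NC(=O)NC1c1ccsc1` gives 201 nM, the lowest number of the three; the steps of a 5.9-fold lower number from compound 1 to compound 3 (0.77 log units; beyond the scatter) and a 7.6-fold lower number from compound 2 to compound 3 (0.88 log units; beyond the scatter) are both beyond the scatter.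

Compound 4 `CC1=C(c2ncc(C)o2)C(c2ccsc2)NC(=O)N1` keeps the thiophen-3-yl of compound 3 and changes the other substituent: 5-methyl-1,3-oxazol-2-yl in place of propoxycarbonyl on a double-bonded ring carbon. For the measured compounds named here, all three measured steps concern the aryl group on the saturated ring carbon; none touches the propoxycarbonyl or the position it occupies, so no measured step bears on this change. Going by the values given here, a chain gives way to a five-membered aromatic ring, and nothing among the measured compounds shows what such a swap does in this assay. The expectation is therefore no step beyond the scatter, held with low confidence and a wide range, the estimated step being a 1.1-fold higher number from compound 3 to compound 4 (0.04 log units; within the scatter). Compound 4 is expected to give about 220 nM in this assay, within a range of 60 nM to 800 nM.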

Compound 4, inhibition constant: 1130 nM
Compound 4: middle estimate off by 5.1-fold (0.71 log units), on the low side, outside the stated range (above it).
By their numbers in this assay, from the lowest: compound 3; then compounds 4, 1 and 2 (each within the scatter of the next).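

In this assay, the group on the double-bonded ring carbon matters: 5-methyl-1,3-oxazol-2-yl in place of propoxycarbonyl gives a 5.6-fold higher number from compound 3 to compound 4 (0.75 log units; beyond the scatter), the first sign that the number depends on this position as well as on the aryl group on the saturated ring carbon. The two groups match in heavy-atom, hydrogen-bond donor and hydrogen-bond acceptor counts, so those counts alone do not set the value here. Nothing at hand explains the step.

With a single replacement at this position, the compounds shown leave open whether the higher number belongs to the oxazole ring itself, to its methyl group, or to the loss of the propoxycarbonyl ester; the unsubstituted 1,3-oxazol-2-yl, ethoxycarbonyl or a propyl amide would help separate these possibilities. Also open, going by these compounds, is whether the same replacement would shift the number to a similar extent with the furan-3-yl of compound 1 or the thiophen-2-yl of compound 2.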